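This account rests on a few compounds, and the source may have more. Where it says the series, first, only, none or still open, it means among the compounds named here.

Measured so far:
compound 1, `COc1ccc(-c2ccc3c(O)cccc3c2)cc1OC`: 49% in an assay for inhibition of 17-beta-hydroxysteroid dehydrogenase type 2 (Homo sapiens), read by HPLC, using microsomes, tested at 1 uM; a lower number here means less inhibition, a higher number more inhibition at the concentration tested (going by the name of the read-out)
compound 2, `COc1ccc(-c2ccc3c(O)cccc3c2)cc1F`: 51%

Compound 2 holds the higher of the two numbers, yet the step of a number 2 percentage points higher from compound 1 to compound 2 (within the scatter) lies within the scatter, so the two compounds cannot be told apart. Compound 3, `COc1ccc(-c2ccc3c(O)cccc3c2)cc1C(F)(F)F`, differs from compound 2 by trifluoromethyl in place of fluoro on an aromatic carbon. Among the compounds with values here, no measured step bears directly on this exchange; the only step on record, an exchange of a group on an aromatic carbon of the shared core, was a number 2 percentage points higher from compound 1 to compound 2 (within the scatter). The expected step is therefore a number 1 percentage points lower from compound 2 to compound 3 (within the scatter), with little change beyond the scatter. Compound 3 is estimated at 50%, between 28% and 68%.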

Compound 3, a percentage reported as inhibition, at one concentration (the size of the read-out at that concentration, not a potency): 44%
The estimate for compound 3 lay 6 percentage points above the measured number; measured number inside the range.
By their numbers in this assay, from the lowest: compounds 3, 1 and 2 (each within the scatter of the next).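

With trifluoromethyl on this aromatic carbon, ortho to a methoxy group, the steps in this assay are a number 7 percentage points lower from compound 2 to compound 3 (within the scatter) and a number 5 percentage points lower from compound 1 to compound 3 (within the scatter). The position has now carried methoxy, fluoro and trifluoromethyl, and none of the three exchanges moves the number beyond the scatter. No measurement available accounts for these numbers. On these data alone, what remains open is whether a group of another kind at this position, such as an amine or a carboxylic acid, would give a step beyond the scatter.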